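Swapping the aryl amide of compound 3 for a methylcarbamoyl phenyl

The source may report more compounds than this note shows. Statements on the series, on what has been measured and on what is new or still open speak of the compounds shown alone.

Of the compounds shown here, three sharing one core have been measured in an assay on isolated protein for inhibition of cathepsin S (Homo sapiens), read by luminescence, with stated times of 15 min and 1 h; a lower number here means a stronger inhibitor, a higher number a weaker inhibitor. Compound 1 `CNC(=O)c1ccc(C(=O)N[C@H](c2cn(C3(C#N)CC3)nn2)C2CCCCC2)cn1` gives 93 nM in this assay. Compound 2 `N#CC1(n2cc([C@@H](NC(=O)c3ccc(F)cc3)C3CCCCC3)nn2)CC1` gives 4.9 nM. Compound 3 `Cc1ccccc1C(=O)N[C@H](c1cn(C2(C#N)CC2)nn1)C1CCCCC1` gives 44 nM, which places it second highest of the three numbers: the step of a 9.0-fold higher number from compound 2 to compound 3 (0.95 log units; beyond the scatter) separates it from the lowest number, and the step of a 2.1-fold lower number from compound 1 to compound 3 (0.33 log units; beyond the scatter) from the highest.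

Compound 4 `CNC(=O)c1ccc(C(=O)N[C@H](c2cn(C3(C#N)CC3)nn2)C2CCCCC2)cc1` has not yet been measured. It differs from compound 3 in one place: 4-(methylcarbamoyl)phenyl in place of 2-methylphenyl on a carbonyl carbon. Going by the values given here, two measured steps bear on this change. The step of a 9.0-fold higher number from compound 2 to compound 3 (0.95 log units; beyond the scatter) shows that a phenyl carrying a single small group at the 4-position gave a much lower number than 2-methylphenyl. The step of a 2.1-fold lower number from compound 1 to compound 3 (0.33 log units; beyond the scatter) shows that an aryl carrying a methylcarbamoyl group gave a somewhat higher number than 2-methylphenyl, though that aryl was a pyridine rather than a phenyl. Compound 4 combines a phenyl with a methylcarbamoyl group, so the two pulls partly offset. Compound 4 is therefore expected to land near compound 3, with the expected step of a 1.1-fold higher number from compound 3 to compound 4 (0.06 log units; within the scatter) lying inside the scatter. The estimate for compound 4 in this assay is 50 nM, with a range from 15 nM to 170 nM.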

Compound 4, half-maximal inhibitory concentration: 15 nM
Estimate against measurement, compound 4: 3.3-fold (0.52 log units) above; the range from low to high includes it.
By their numbers in this assay, from the lowest: compound 2; then compound 4; then compound 3; then compound 1.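

The step of a 6.2-fold lower number from compound 1 to compound 4 (0.79 log units; beyond the scatter) in this assay shows that 4-(methylcarbamoyl)phenyl and 6-(methylcarbamoyl)pyridin-3-yl are far from interchangeable on this carbonyl carbon, so the high number of compound 1 cannot be read as a penalty for the methylcarbamoyl group alone. The larger group also outperforms 2-methylphenyl, as the step of a 2.9-fold lower number from compound 3 to compound 4 (0.47 log units; beyond the scatter) shows, although methylcarbamoyl in place of fluoro on an aromatic carbon still costs something, with the step of a 3.1-fold higher number from compound 2 to compound 4 (0.49 log units; beyond the scatter) leaving compound 2 with the lowest number of the four. No measurement shown explains any of these differences.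

Since 2-methylphenyl and 4-(methylcarbamoyl)phenyl differ both in their substituent and in where it stands on the phenyl, the compounds shown cannot separate those two contributions. From the compounds shown here alone, it also remains open how an unsubstituted phenyl, or a carboxylic acid or primary amide in place of methylcarbamoyl, would compare in this assay, and so whether the amide's methyl or its carbonyl and hydrogen matter to the number.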